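The source may hold more compounds than are shown below. What is called first, only, known or untested is meant among the compounds shown, and "the series" means these compounds.

In a functional assay on the whole organism with Rattus norvegicus as the target, with a stated time of 3 h (a higher number here means that more compound is needed for the effect, a lower number that less compound is needed), compound 1 `CO[C@]1(c2cc(F)cc(Sc3ccc(/C(C)=N/O)cc3)c2)CCO[C@@H](C)C1` gives 0.05 mg/kg. Compound 2 `CO[C@]1(c2cc(F)cc(Sc3ccc(/C(C)=N/OCC#N)cc3)c2)CCO[C@@H](C)C1` differs from compound 1 at a single point, the change (hydrogen in place of cyanomethyl on an oxygen), and in this assay compound 2 gives 0.15 mg/kg. The step of a 3.0-fold lower number from compound 2 to compound 1 (0.48 log units; beyond the scatter) shows that, with the cyanomethyl group gone, less compound was needed for the effect. Compound 3 `CO[C@]1(c2cc(F)cc(S(=O)(=O)c3ccc(/C(C)=N/OCC#N)cc3)c2)CCO[C@@H](C)C1` carries the cyanomethyl group on a different core; the difference between the cores of compound 2 and compound 3 is not broken down here. In this assay compound 3 gives 0.1 mg/kg, a number that sits within the usual scatter of the value for compound 2. Compound 4 `CO[C@]1(c2cc(F)cc(S(=O)(=O)c3ccc(/C(C)=N/O)cc3)c2)CCO[C@@H](C)C1` has not yet been measured. It stands to compound 3 exactly as compound 1 stands to compound 2, through the change (hydrogen in place of cyanomethyl on an oxygen), made at the same place. Resting on the step of a 3.0-fold lower number from compound 2 to compound 1 (0.48 log units; beyond the scatter) already seen for that change, the expected step for compound 4 is a 2.9-fold lower number from compound 3 to compound 4 (0.46 log units; beyond the scatter). The estimate for compound 4 in this assay is therefore 0.035 mg/kg, with a likely range from 0.015 mg/kg to 0.1 mg/kg.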

Compound 4, dose for half-maximal effect: 0.1 mg/kg
Beside the measured number, compound 4's estimate is 2.9-fold (0.46 log units) below it, within the range that was stated.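

In this assay, putting hydrogen in place of cyanomethyl on the oxygen gives no change at the digits printed from compound 3 to compound 4 (within the scatter), so the drop in the dose needed on the core of compound 1 does not reappear on the core of compound 3, and the two steps differ by more than the scatter allows: the same change on two cores in this assay, a 3.0-fold lower number (0.48 log units; beyond the scatter) from compound 2 to compound 1 and no change at the digits printed (within the scatter) from compound 3 to compound 4, 3.0-fold (0.48 log units) apart, beyond the scatter of two such steps

This shows that, in these two pairs, the size of the step depends on the core it is made on, so a step read from one core cannot be assumed for the other. Among these compounds, it does not show why the cores behave differently, and with only two pairs it gives no general rule for the series.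

The compounds shown leave open how a methyl group, or a longer chain ending in a carboxylic acid, would behave on that oxygen on either core. They also leave open whether such groups would show the same difference between the two cores.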